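The source may report more compounds than this note shows. Statements on the series, on what has been measured and on what is new or still open speak of the compounds shown alone.

- compound 1 `Cn1cc(-c2ncc(C#N)c(N3C[C@@H]4C[C@H]3CN4S(=O)(=O)C3CC3)n2)cn1`: < 36 mL/min/kg (a limit of the assay, not a number)
- compound 2 `C[C@@H]1C[C@H]1C(=O)N1CCN(c2nc(-c3cnn(C)c3)ncc2C#N)C[C@H]1C`: 54 mL/min/kg
- compound 3 `C[C@@H]1CN(c2nc(-c3cnn(C)c3)cnc2C#N)CCN1C(=O)C1CC1`: 39 mL/min/kg

These results come from an ADME assay on microsomes from liver (Rattus norvegicus) for pharmacokinetics; on this read-out lower numbers stand for slow clearance and higher numbers for fast clearance. Compound 2 at 54 mL/min/kg and compound 3 at 39 mL/min/kg lie within the usual scatter of repeated measurements, so these two numbers cannot be told apart. Compound 1 is reported only as a limit, < 36 mL/min/kg.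

Compound 4 `CCC(=O)N1CCN(c2nc(-c3cnn(C)c3)ncc2C#N)C[C@H]1C` has not yet been measured. It differs from compound 2 in one place, with ethyl in place of 2-methylcyclopropyl on a carbonyl carbon. The same difference, cut one bond further out, reads (2-methylcyclopropyl)carbonyl to propanoyl.

Going by the values given here, no two measured compounds differ in only one place, so these data do not size this kind of change directly. The expectation therefore starts from compound 2 at 54 mL/min/kg, the closest reference point for this change. A small step is expected in this assay, slightly downward and not beyond the scatter: a 1.2-fold lower number from compound 2 to compound 4 (0.08 log units; within the scatter). A result reported only as a limit is also possible. The estimated clearance of compound 4 is 45 mL/min/kg, with an expected range of 30 mL/min/kg to 68 mL/min/kg.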

Compound 4, clearance: < 36 mL/min/kg
Compound 4 was reported as a limit; the forecaster's own chance of this, stated with the estimate: 20%; middle value at least 1.2-fold (0.09 log units) away from the limit.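

Swapping 2-methylcyclopropyl for ethyl on the carbonyl carbon, a carbon whose other neighbour is an amide-type nitrogen in a ring, gives the only direct reading of a one-place change among these compounds in this assay: an at least 1.5-fold lower number from compound 2 to compound 4 (0.17 log units; that floor lies within the scatter). This change removes the three-membered ring and its two defined stereocentres, and clearance does not rise in this pair, though the printed step is only a floor that does not clear the usual scatter. Compound 4 is reported as a limit and not a number, and its true distance from compound 2 cannot be sized because the result rests on the limit of the assay: the limit of < 36 mL/min/kg in this assay, at which 2 of the 4 values shown sit.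

Going by these compounds alone, the single pair leaves open whether the ring, its methyl group or the size of the group as a whole accounts for the step, and it cannot show how far the clearance of compound 4 really lies from that of compound 2. Methyl or a longer chain such as butyl on the same carbonyl carbon, or an amine placed on that chain, would test whether this pair reflects a wider trend at this position.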